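The compounds below may be only part of what the source reports. "The series", "measured", "known", "first", "only" and "open" are said of these compounds alone.

Compound 1 `O=C(CSc1ncccn1)N/N=c1/scc(-c2ccc(Br)cc2)n1-c1ccccc1` carries a pyrimidin-2-yl group on a sulfur. In a functional assay on C6 cells (Rattus norvegicus) for cytotoxicity, read by MTT assay, with a stated time of 24 h (on this read-out higher numbers stand for weaker inhibition and lower numbers for stronger inhibition), compound 1 gives only a limit of the assay, > 200 ug/mL, so no single number is known for it (the limit of > 200 ug/mL in this assay, at which 1 of the 3 values shown sits). Compound 2 `Cc1nnc(SCC(=O)N/N=c2/scc(-c3ccc(Br)cc3)n2-c2ccccc2)s1` has a different sulfur-linked group; in this assay compound 2 gives "not determined" (no result reported). Compound 3 `O=C(CSc1nnnn1-c1ccccc1)N/N=c1/scc(-c2ccc(Br)cc2)n1-c1ccccc1` has a 1-phenyl-1H-tetrazol-5-yl in place of the pyrimidin-2-yl on the sulfur, and in this assay compound 3 gives 21 ug/mL, a step of an at least 9.5-fold lower number from compound 1 to compound 3 (0.97 log units; beyond the scatter).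

Compound 4 `O=C(CSc1ncccn1)N/N=c1/scc(-c2ccc(Cl)cc2)n1-c1ccccc1` differs from compound 1 in one place: chloro in place of bromo on an aromatic carbon. Among the compounds with values here, none of the measured steps touches the bromo; the one measured step alters the group on the sulfur and so offers no guide to swapping bromo for chloro. With nothing to point to a change in either direction, the expectation is a step that stays within the scatter. Compound 4 is therefore estimated to give 250 ug/mL in this assay, with a range from 100 ug/mL to 600 ug/mL, and most probably again only a limit. The step expected from compound 1 to compound 4 is a step that the limit leaves unreadable from compound 1 to compound 4.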

Compound 4, half-maximal inhibitory concentration: 83.3 ug/mL
The estimate for compound 4 lay 3.0-fold (0.48 log units) above the measured number; measured number below the stated range.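

Within the data shown here, until this result, the only measured change lay on the sulfur, and nothing showed whether the bromo on the aromatic ring had any bearing on the read-out in this assay. It does: with the pyrimidin-2-yl kept on the sulfur, going from 4-bromophenyl to 4-chlorophenyl gives an at least 2.4-fold lower number from compound 1 to compound 4 (0.38 log units; beyond the scatter), so even replacing one halogen atom with another, with no change in ring or net charge, can move the number beyond the usual scatter. The full size of this step cannot be read, because compound 1 stands at a limit and not at a single number: the limit of > 200 ug/mL in this assay, at which 1 of the 4 values shown sits.

Going by these compounds, it remains open whether chloro in place of bromo would also lower the number with a 1-phenyl-1H-tetrazol-5-yl on the sulfur, so this single step cannot be taken as a general rule for the series. On these data alone, it is also open where a 4-fluorophenyl, a 4-methoxyphenyl or a plain phenyl group would fall in this assay, and so whether the effect is specific to chloro or is shared by other groups at this place.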